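The compounds below may be only part of what the source reports. "The series", "measured", "known", "first", "only" and "open" are said of these compounds alone.

Working notes on the dihydropyridine series (the core is shared; its structure stands with each compound).

For the measured compounds named here, compound 2 `COC(=O)C1=C(C)N=C(C)/C(=C(\O)OC)C1c1cccc(C)c1` is the higher of the two numbers so far in a functional assay (muscle tissue) with Cavia porcellus as the target; a higher number here means that more compound is needed for the effect, a lower number that less compound is needed: in this assay compound 2 gives 110 nM. Going by the values given here, its only neighbour is compound 1 `COC(=O)C1=C(C)N=C(C)/C(=C(\O)OC)C1c1ccccc1Cl`, which in this assay gives 2.19 nM, so the one measured step runs a 50-fold higher number from compound 1 to compound 2 (1.70 log units; beyond the scatter).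

Compound 3 `COC(=O)C1=C(C)N=C(C)/C(=C(\O)OC)C1c1ccc(Cl)cc1Cl` is not yet measured. It differs from compound 2 as follows: 2,4-dichlorophenyl in place of 3-methylphenyl on a saturated ring carbon. The change therefore puts a chlorine-bearing phenyl back on the saturated ring carbon, as in compound 1, with a second chlorine added in the 2,4-dichlorophenyl group. Among the compounds with values here, the only step that bears on this is the large one from compound 1 to compound 2, a 50-fold higher number from compound 1 to compound 2 (1.70 log units; beyond the scatter), which went in the opposite direction; nothing measured here tells what the second chlorine adds or takes away. On that basis a large step back toward the number of compound 1 is expected, a 37-fold lower number from compound 2 to compound 3 (1.56 log units; beyond the scatter), with room for the second chlorine to shift it either way. Compound 3 is estimated at 3 nM in this assay, within 0.7 nM to 15 nM.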

Compound 3, half-maximal effective concentration: 640 nM
Beside the measured number, compound 3's estimate is 210-fold (2.33 log units) below it; the whole stated range lies below it.
By their numbers in this assay, from the lowest: compound 1; then compound 2; then compound 3.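

In this assay, chloro in place of hydrogen on an aromatic carbon gives a 290-fold higher number from compound 1 to compound 3 (2.47 log units; beyond the scatter), so a chlorine-bearing phenyl on the saturated ring carbon does not by itself keep the low number of compound 1, and the added chlorine of the 2,4-dichlorophenyl group carries a large cost here. The change from 3-methylphenyl to 2,4-dichlorophenyl gives a 5.8-fold higher number from compound 2 to compound 3 (0.76 log units; beyond the scatter), which places compound 3 at the top of the three numbers and shows that, among these compounds, the number at this position follows which groups the phenyl carries and where they stand, not simply whether chlorine is present. Nothing available on these compounds speaks to the reason for either step.

On these data alone, it remains open whether a 4-chlorophenyl group, without the second chlorine, would carry the same high number as the 2,4-dichlorophenyl group or would fall nearer to the 2-chlorophenyl group. Also open, as far as these compounds go, is how a methoxy group or an amine on the phenyl would compare with chloro and methyl, and whether a carboxylic acid in place of the methoxycarbonyl group would leave these steps unchanged.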